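Oxime series: ethyl to 2-chlorobenzyl, compound 4 estimate

A few compounds are considered here, and "the series" means these few. Any claim that something is new, unique, unknown or untested is made for them only; others in the source may bear on it.

Compound 1 `CCn1cc(COc2cc(O)c3c(c2)O[C@H](c2ccc(OC)c(O)c2)C/C3=N\O)nn1` is the oxime that carries an ethyl group; in a functional assay on RAW264.7 cells (Mus musculus) for inhibition, read by Griess assay, with stated times of 2 h and 24 h (a lower number here means a stronger inhibitor, a higher number a weaker inhibitor), compound 1 gives 3140 nM. Compound 2 `COc1ccc([C@@H]2CC(=O)c3c(O)cc(OCc4cn(Cc5ccccc5Cl)nn4)cc3O2)cc1O`, a ketone carrying 2-chlorobenzyl, gives 6140 nM in this assay, which sits within the scatter of the number for compound 1. Compound 3 `COc1ccc([C@@H]2CC(=O)c3c(O)cc(OCc4cn(Cc5ccc(Cl)cc5)nn4)cc3O2)cc1O` is the 4-chlorophenyl counterpart of compound 2; in this assay compound 3 gives 17800 nM. For the measured compounds named here, the step of a 2.9-fold higher number from compound 2 to compound 3 (0.46 log units; beyond the scatter) is the only single change measured so far, and compound 3 also stands beyond the scatter from compound 1.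

Compound 4 `COc1ccc([C@@H]2C/C(=N\O)c3c(O)cc(OCc4cn(Cc5ccccc5Cl)nn4)cc3O2)cc1O` is reached from compound 1 by 2-chlorophenyl in place of methyl on a saturated chain carbon bound to an aromatic nitrogen. Going by the values given here, no measured step covers this ethyl to 2-chlorobenzyl change directly. Compound 1 and compound 2 differ in two places, the oxime against the ketone and the ethyl against the 2-chlorobenzyl, and their two values lie within the scatter of each other, so the combined change reads as no change. The step of a 2.9-fold higher number from compound 2 to compound 3 (0.46 log units; beyond the scatter) concerns the exchange of 4-chlorophenyl for 2-chlorophenyl within the ketone series and does not inform the change to compound 4. The expectation is therefore a step of a 1.3-fold higher number from compound 1 to compound 4 (0.11 log units; within the scatter) of no size beyond the scatter. Compound 4 is estimated at 4000 nM, with a range of 1500 nM to 11000 nM.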

Compound 4, half-maximal inhibitory concentration: 13400 nM
For compound 4 the middle estimate is 3.4-fold (0.53 log units) below the measured one; the whole stated range lies below it.
By their numbers in this assay, from the lowest: compounds 1 and 2 (each within the scatter of the next); then compounds 4 and 3 (each within the scatter of the next).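

In this assay, for the compounds shown here, the oxime series shows a 4.3-fold higher number from compound 1 to compound 4 (0.63 log units; beyond the scatter) as the first direct reading of this change, on a saturated chain carbon bound to an aromatic nitrogen. Within the oxime series, then, ethyl to 2-chlorobenzyl carries a cost beyond the scatter, something the comparison of compound 1 with compound 2 could not show, as those two compounds differ in two places. No supporting measurement is available that would account for this step.

With only ethyl and 2-chlorobenzyl to compare among the oximes, the compounds shown leave open whether the higher number goes with the added aromatic ring, with the chlorine, or with the larger group as a whole. An unsubstituted benzyl, a longer chain such as n-butyl and a chain ending in an amine would help separate these readings at this position, while a 4-chlorobenzyl oxime would show whether the step seen among the ketones, a 2.9-fold higher number from compound 2 to compound 3 (0.46 log units; beyond the scatter), also holds in the oxime series.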